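The source may report more compounds than this note shows. Statements on the series, on what has been measured and on what is new or still open speak of the compounds shown alone.

Measured so far in a functional assay on MOLT-4F cells (Homo sapiens) for antiproliferative activity; a lower number here means a stronger inhibitor of growth, a higher number a weaker inhibitor of growth:
- compound 1 `COCCCCCCCCCCCCCCC/C=C1/CC(CO)(COC(=O)C(C)(C)C)OC1=O`: 1.64 ug/mL
- compound 2 `CCCCCOCCCCCCC/C=C1\CC(CO)(COC(=O)C(C)(C)C)OC1=O`: 1.03 ug/mL
- compound 3 `CC(C)(C)C(=O)OCC1(CO)C/C(=C\CCCCCCCCCCCCCCC=O)C(=O)O1`: > 10 ug/mL

Compound 1 and compound 2 lie within the usual scatter of each other. Compound 3 gives no exact number, only (the limit of > 10 ug/mL in this assay, at which 1 of the 3 values shown sits).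

Compound 4 `CC(C)(C)C(=O)OCC1(CO)C/C(=C/CCCCCCCCCCCCCCC=O)C(=O)O1` has the same atoms and bonds as compound 3, and only the double bond differs: the two compounds have the same atoms and bonds; at least one stereo element is drawn with a configuration in one of them and without one in the other: 1 of 2 stereo elements differ; a double bond is drawn E in compound 3 and Z in compound 4.

Going by the values given here, the one measured step reaching compound 3 is an at least 9.7-fold higher number from compound 2 to compound 3 (0.98 log units; beyond the scatter), which brought in the 7-formylheptyl group. Compound 4 keeps that group, so it is expected to remain a weak growth inhibitor in this assay. The expected change is a number no higher from compound 3 to compound 4 (the limit leaves the size open), with none beyond the scatter anticipated. For compound 4 the estimate is 10 ug/mL, with an estimated range of 4 ug/mL to 20 ug/mL.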

Compound 4, concentration for 50% growth inhibition: 2.02 ug/mL
The estimate for compound 4 lay 5.0-fold (0.69 log units) above the measured number, and the stated range ends above it.
By their numbers in this assay, from the lowest: compounds 2, 1 and 4 (each within the scatter of the next). At a limit, above all of these: compound 3.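

In this assay, double-bond geometry alone separates two compounds with the same formyl-ended chain: an at least 4.9-fold lower number from compound 3 to compound 4 (0.69 log units; beyond the scatter). Compound 3 is recorded only as a limit, > 10 ug/mL. With formyl in place of methoxymethyl, the formyl group is compatible with growth inhibition in this series: a 1.2-fold higher number from compound 1 to compound 4 (0.09 log units; within the scatter).

As far as these compounds go, it remains open whether a carboxylic acid or an amine in place of formyl would keep this level of growth inhibition in this assay, or whether geometry matters as much with other chain ends. The geometry comparison also carries a caveat: the fact that one of compounds 3 and 4 is drawn with a defined configuration and the other without, at the place where they differ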